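The source may hold more compounds than are shown below. What is called first, only, known or untested is meant among the compounds shown, and "the series" means these compounds.

Compound 1 `Fc1ccc(-c2nn(-c3ccccc3)cc2-c2nc3ccccc3[nH]2)cc1` gives 2330 nM in a functional assay on HeLa cells (Homo sapiens) for antiproliferative activity, read by MTT assay, with a stated time of 48 h; on this read-out higher numbers stand for weaker inhibition and lower numbers for stronger inhibition. Compound 2 `Cc1ccc2[nH]c(-c3cn(-c4ccccc4)nc3-c3ccc(F)cc3)nc2c1` gives 3630 nM in this assay. Compound 3 `Cc1ccc2[nH]c(-c3cn(-c4ccccc4)nc3-c3ccc(Cl)cc3)nc2c1` gives 5360 nM in this assay.

From compound 1 to compound 2 the change is methyl in place of hydrogen on an aromatic carbon and it made a 1.6-fold higher number from compound 1 to compound 2 (0.19 log units; within the scatter). From compound 2 to compound 3 the change is chloro in place of fluoro on an aromatic carbon, with a 1.5-fold higher number from compound 2 to compound 3 (0.17 log units; within the scatter). The difference between the cores of compound 1 and compound 3 is not broken down here.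

Compound 4 `Cc1cc2nc(-c3cn(-c4ccccc4)nc3-c3ccc(Cl)cc3)[nH]c2cc1C` is not yet measured. It differs from compound 3 by methyl in place of hydrogen on an aromatic carbon. This is the same kind of change as from compound 1 to compound 2, but here the place is also ortho to a methyl group, so it is not the same. Because a 1.6-fold higher number from compound 1 to compound 2 (0.19 log units; within the scatter) was small, a step of about a 1.3-fold higher number from compound 3 to compound 4 (0.12 log units; within the scatter) is expected. Compound 4 is estimated at 7000 nM, between 3500 nM and 14000 nM.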

Compound 4, half-maximal inhibitory concentration: 21800 nM
For compound 4 the middle estimate is 3.1-fold (0.49 log units) below the measured one; measured number above the stated range.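

In this assay the added methyl group gave a 4.1-fold higher number from compound 3 to compound 4 (0.61 log units; beyond the scatter) and so weaker inhibition on the core of compound 3. Set beside the same change on the other core, the two steps cannot be told apart: the same change on two cores in this assay, a 1.6-fold higher number (0.19 log units; within the scatter) from compound 1 to compound 2 and a 4.1-fold higher number (0.61 log units; beyond the scatter) from compound 3 to compound 4, 2.6-fold (0.42 log units) apart, within the scatter of two such steps. This fits a methyl effect that carries from one core to the other, but two pairs do not show that the step has a fixed size, and the new methyl group here also sits ortho to a methyl group.

The compounds shown leave open how a different group on this ring, such as a methoxy group, an amine or a carboxylic acid, would behave. They also leave open whether any such group would lower the number.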